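Chloro on a double-bonded chain carbon of compound 3

A few compounds are considered here, and "the series" means these few. Any claim that something is new, unique, unknown or untested is made for them only; others in the source may bear on it.

Compound 1 `C/C=C\C(=O)Nc1cc(Nc2nc3c(c(-c4cn(C)c5ccc(F)cc45)n2)CSCC3)c(OC)cc1N(C)CCN(C)C`: 5310 nM
Compound 2 `CCC/C=C\C(=O)Nc1cc(Nc2nc3c(c(-c4cn(C)c5ccc(F)cc45)n2)CSCC3)c(OC)cc1N(C)CCN(C)C`: 5190 nM
Compound 3 `C=CC(=O)Nc1cc(Nc2nc3c(c(-c4cn(C)c5ccccc45)n2)CS(=O)(=O)CC3)c(OC)cc1N(C)CCN(C)C`: 8690 nM

In a functional assay on A549 cells (Homo sapiens) for inhibition, read by MTT assay, with a stated time of 72 h (on this read-out higher numbers stand for weaker inhibition and lower numbers for stronger inhibition), compound 3 gives 8690 nM, which lies within the usual scatter of compound 1 at 5310 nM and of compound 2 at 5190 nM. Among the compounds with values here, these three numbers therefore set no order among the compounds.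

Compound 4 `C=C(Cl)C(=O)Nc1cc(Nc2nc3c(c(-c4cn(C)c5ccccc45)n2)CS(=O)(=O)CC3)c(OC)cc1N(C)CCN(C)C` differs from compound 3 in one place: chloro in place of hydrogen on a double-bonded chain carbon bound to a carbonyl carbon.

Within the data shown here, only one measured step offers any guide. That step, a 1.0-fold lower number from compound 1 to compound 2 (0.01 log units; within the scatter), puts ethyl in place of hydrogen on a saturated chain carbon bound to a double-bonded chain carbon, and it stays within the scatter. Among the measured compounds shown here, it is a different change at a different place, and no measured compound carries this chloro, so it is weak evidence. With nothing pointing either way, no step beyond the scatter is expected in this assay. The expected change is small, a 1.2-fold lower number from compound 3 to compound 4 (0.06 log units; within the scatter), with no firm direction. The estimate for compound 4 is 7500 nM, with an expected range from 3200 nM to 17000 nM.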

Compound 4, half-maximal inhibitory concentration: 881 nM
Estimate against measurement, compound 4: 8.5-fold (0.93 log units) above, outside the stated range (below it).
By their numbers in this assay, from the lowest: compound 4; then compounds 2, 1 and 3 (each within the scatter of the next).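

In this assay, chloro in place of hydrogen on a double-bonded chain carbon bound to a carbonyl carbon gives a 9.9-fold lower number from compound 3 to compound 4 (0.99 log units; beyond the scatter), so a change of only 1 heavy atom at this place moves the number beyond the usual scatter. Within the data shown here, the earlier compounds could not show this sensitivity: their only step, a 1.0-fold lower number from compound 1 to compound 2 (0.01 log units; within the scatter), involves ethyl on a saturated chain carbon, a different change at a different place, and stays within the scatter. No accompanying measurement bears on what lies behind the effect of the chloro.

As far as these compounds go, whether the step belongs to chloro in particular remains open, and bromo, fluoro or methyl on the same double-bonded chain carbon would help to answer that. Among these compounds, also open is whether chloro at this place would produce a similar step on the core of compound 1, since the only pair that shows the change shares the core of compound 3.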